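The source may report more compounds than this note shows. Statements on the series, on what has been measured and on what is new or still open speak of the compounds shown alone.

Measured so far:
compound 1 `O=C(O)c1cn(C2CC2)c2c(Cl)c(N3CCCC3)c(F)cc2c1=O`: 150 ug/mL
compound 2 `O=C(O)c1cn(C2CC2)c2c(F)c(N3CCNCC3)c(F)cc2c1=O`: 47 ug/mL

Both compounds were tested in a functional assay on V79 cells (Cricetulus griseus) for cytotoxicity, read by colony formation; a higher number here means a weaker inhibitor, a lower number a stronger inhibitor. Compound 2, at 47 ug/mL, holds the lower of the two numbers, which makes it the stronger inhibitor of this pair. The gap to compound 1, at 150 ug/mL, lies beyond the scatter. For the measured compounds named here, no two measured compounds differ in one place only, so no single change has yet been measured on its own.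

The next compound is compound 3 `O=C(O)c1cn(C2CC2)c2c(Cl)c(N3CCNCC3)c(F)cc2c1=O`. It keeps the piperazin-1-yl group of compound 2 but has chloro in place of fluoro on an aromatic carbon. Going by the values given here, with no direct precedent for this swap, the change expected in this assay is small and stays within the scatter. There is a slight lean towards a higher number, given that compound 1, which also carries chloro, reads 150 ug/mL. The estimated step is a 1.3-fold higher number from compound 2 to compound 3 (0.11 log units; within the scatter). For compound 3 the estimated value is 60 ug/mL, with an expected range of 25 ug/mL to 140 ug/mL.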

Compound 3, half-maximal inhibitory concentration: 43 ug/mL
Compound 3: the middle estimate sits 1.4-fold (0.14 log units) above what was measured; the range from low to high includes it.
By their numbers in this assay, from the lowest: compounds 3 and 2 (each within the scatter of the next); then compound 1.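

In this assay, chloro in place of fluoro on the aromatic carbon ortho to a piperazin-1-yl group gives a 1.1-fold lower number from compound 2 to compound 3 (0.04 log units; within the scatter), so with piperazin-1-yl present, these two halogens cannot be told apart at this position. For the compounds shown here, with chloro held constant, piperazin-1-yl in place of pyrrolidin-1-yl gives a 3.5-fold lower number from compound 1 to compound 3 (0.54 log units; beyond the scatter), the first single change here that lies beyond the scatter, which shows that this amine ring matters more in this pair than the halogen does in the other. Nothing available explains the size of either step.

On these data alone, whether chloro and fluoro would also read alike with pyrrolidin-1-yl on the neighbouring ring carbon remains open, as a single pair cannot show whether the halogen result carries over to another amine ring. Also open, as far as these compounds go, is what a methoxy group or a plain hydrogen would do in place of the halogen, and what a morpholin-4-yl group or an open-chain amine would do in place of piperazin-1-yl.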